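Propyl to isopropyl on the core of compound 1

The source may hold more compounds than are shown below. What is called first, only, known or untested is meant among the compounds shown, and "the series" means these compounds.

Two compounds have numbers in a functional assay on the whole organism for inhibition, with Spinacia oleracea as the target, read by spectrophotometry, with a stated time of 4 h (a lower number here means a stronger inhibitor, a higher number a weaker inhibitor), so far. Compound 1 `CCCc1cnc(C(=O)/C=C/c2ccc(O)cc2)cn1` gives 399000 nM in this assay, the higher of the two. Compound 2 `CCCCCCCCSc1cc(C(N)=S)ccn1`, a different scaffold altogether, gives 72000 nM in this assay, a lower number by a gap beyond the usual scatter. Among the compounds with values here, no pair that differs in one place has been measured yet, so no step size is known from.

Compound 3 `CC(C)c1cnc(C(=O)/C=C/c2ccc(O)cc2)cn1` keeps the core of compound 1 and differs only in the alkyl group: isopropyl in place of propyl on an aromatic carbon. A change of this kind, rearranging three carbons without altering their count, donors or acceptors, is expected to move the number little, if at all, in this assay; no direction beyond the scatter is expected.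

Compound 3 is therefore expected to give about 380000 nM in this assay, within 150000 nM to 950000 nM. The expected step of a 1.1-fold lower number from compound 1 to compound 3 (0.02 log units; within the scatter) is estimated to stay inside the scatter.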

Compound 3, half-maximal inhibitory concentration: 315000 nM
The estimate for compound 3 lay 1.2-fold (0.08 log units) above the measured number, and the stated range covers the measured number.
By their numbers in this assay, from the lowest: compound 2; then compounds 3 and 1 (each within the scatter of the next).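

In this assay, within the data shown here, the only step so far is a 1.3-fold lower number from compound 1 to compound 3 (0.10 log units; within the scatter), for isopropyl in place of propyl on an aromatic carbon next to the ring nitrogen. The step gives the series its first reading at this position: this swap of one three-carbon alkyl group for the other leaves the number within the scatter, so the two compounds cannot be ranked. No measurement on hand bears on why the number holds.

The compounds shown leave open whether a longer chain such as octyl at this position, or an amine or a carboxylic acid in place of the alkyl group, would move the number beyond the scatter. They also leave open how far the shared core tolerates change anywhere else.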